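Acyl variation on the shared core: plasma half-life notes

The source may hold more compounds than are shown below. What is called first, only, known or untested is meant among the compounds shown, and "the series" means these compounds.

Measured so far in an ADME assay on a cell-free system (plasma, Homo sapiens) for metabolic stability, read by HPLC; on this read-out higher numbers stand for a longer-lived compound and lower numbers for a shorter-lived compound: compound 1 `CC(=O)N[C@@H](C)C(=O)N(C)/N=N/c1ccc(C(N)=O)cc1` gives 7.6 h; compound 2 `CCC(=O)N[C@@H](C)C(=O)N(C)/N=N/c1ccc(C#N)cc1` gives 1.3 h; compound 3 `CC(=O)NCC(=O)N(C)/N=N/c1ccc(C#N)cc1` gives 1.2 h.

Compound 2 stands second highest of the three numbers. Its nearest neighbour is compound 3, reached by a 1.1-fold lower number from compound 2 to compound 3 (0.03 log units; within the scatter), a change on the same carbonyl carbon. Among the compounds with values here, compound 1 lies furthest from compound 2, but the two differ in more than one place, so the pair yields no single step.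

Compound 4 `C[C@H](NC(=O)c1ccccc1)C(=O)N(C)/N=N/c1ccc(C#N)cc1` differs from compound 2 by phenyl in place of ethyl on a carbonyl carbon. Within the data shown here, the only step that bears on this position, a 1.1-fold lower number from compound 2 to compound 3 (0.03 log units; within the scatter), stayed within the scatter, and no measured pair covers a ring entering here. In this assay compound 4 is therefore expected to show no change at the digits printed from compound 2 to compound 4 (within the scatter). The estimate for compound 4 is 1.3 h, within 0.6 h to 2.8 h.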

Compound 4, half-life: 1.6 h
For compound 4 the middle estimate is 1.2-fold (0.09 log units) below the measured one; the measured number falls inside the stated range.
By their numbers in this assay, from the lowest: compounds 3, 2 and 4 (each within the scatter of the next); then compound 1.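

In this assay, benzoyl in place of propanoyl gives a 1.2-fold higher number from compound 2 to compound 4 (0.09 log units; within the scatter) and so extends the picture at this carbonyl carbon from open chains to a six-membered aromatic ring. With this result, both steps read at this position stay within the scatter, including one that enters a ring. No available evidence accounts for this.

From the compounds shown here alone, whether an acyl group carrying an amine or a carboxylic acid would also stay within the scatter remains open. The same applies to a longer chain in place of ethyl.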